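Changing the sulfonamide ring of compound 3

The source may hold more compounds than are shown below. What is called first, only, known or untested is meant among the compounds shown, and "the series" means these compounds.

Three compounds have values so far in a physicochemical assay for solubility (on this read-out higher numbers stand for higher solubility and lower numbers for lower solubility), as follows:
- compound 1 `CN1CCN(c2cc(C(F)(F)F)ccc2[C@H]2CCOc3cc(S(=O)(=O)Nc4nccs4)ccc32)CC1` gives 176000 nM
- compound 2 `O=S(=O)(Nc1nccs1)c1ccc2c(c1)OCC[C@H]2c1ccc(C(F)(F)F)cc1-n1ccnn1` gives 154000 nM
- compound 3 `Cn1nccc1-c1cc(C(F)(F)F)ccc1[C@H]1CCOc2cc(S(=O)(=O)Nc3nccs3)ccc21` gives 83000 nM

Compound 3 at 83000 nM lies within the usual scatter of compound 2 and beyond the scatter below compound 1. The next compound to be measured is compound 4 `Cn1nccc1-c1cc(C(F)(F)F)ccc1[C@H]1CCOc2cc(S(=O)(=O)Nc3ccc(F)cn3)ccc21`, which differs from compound 3 in a single group, with 5-fluoropyridin-2-yl in place of 1,3-thiazol-2-yl on a sulfonamide nitrogen in the structures.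

Among the compounds with values here, all three measured compounds carry the 1,3-thiazol-2-yl group, so no measured step shows what replacing it does. Within the data shown here, the only step available is a 2.1-fold lower number from compound 1 to compound 3 (0.33 log units; beyond the scatter) and it concerns a different place, an aromatic carbon that exchanges 4-methylpiperazin-1-yl for 1-methyl-1H-pyrazol-5-yl. Among the measured compounds shown here, it shows only that one exchange can shift this assay by a modest amount. A step beyond the scatter is therefore not expected, although the range must stay wide and the direction is uncertain. The estimated change is a 1.3-fold lower number from compound 3 to compound 4 (0.11 log units; within the scatter) as a best guess. For compound 4 the estimate is 65000 nM and the value is expected to lie between 22000 nM and 190000 nM.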

Compound 4, solubility: 29000 nM
Estimate against measurement, compound 4: 2.2-fold (0.35 log units) above; measured number inside the range.
By their numbers in this assay, from the lowest: compound 4; then compounds 3, 2 and 1 (each within the scatter of the next, the first and the last beyond it).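

Exchanging the ring on the sulfonamide nitrogen changes the number in this assay, with a 2.9-fold lower number from compound 3 to compound 4 (0.46 log units; beyond the scatter), so this position can move the read-out by more than the usual scatter, although the step is still a modest one. The change replaces 1,3-thiazol-2-yl, a five-membered aromatic ring with 2 hetero atoms, by 5-fluoropyridin-2-yl, a six-membered aromatic ring with 1 hetero atom, and the 1-methyl-1H-pyrazol-5-yl group and the rest of the structure stay the same, which ties the step to this one place. No measured property is available to explain the step.

Going by these compounds, a single exchange alters the ring size, the hetero atoms and the fluorine together, so it remains open which of these matters; a plain pyridin-2-yl or a pyrimidin-2-yl on the same nitrogen would help to separate them. On these data alone, it also remains open whether 5-fluoropyridin-2-yl gives a similar step when 4-methylpiperazin-1-yl, as in compound 1, stands in place of the 1-methyl-1H-pyrazol-5-yl group.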